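The compounds below may be only part of what the source reports. "The series", "measured", "known", "first", "only" and "open" are said of these compounds alone.

Measured so far in a toxicity assay on WI-38 cells (Homo sapiens) for cytotoxicity, read by MTT assay, with a stated time of 48 h; on this read-out higher numbers stand for weaker inhibition and lower numbers for stronger inhibition:
Compound 1 `COc1ccc(Cn2nnnc2C(Nc2ccc([Se][Se]c3ccc(NC(c4ccc(C)cc4)c4nnnn4Cc4ccc(OC)cc4OC)cc3)cc2)c2ccc(C)cc2)c(OC)c1` returns >= 100000 nM, which is a limit of the assay and not a number.
Compound 2 `CC1=C([Se]c2ccc(NCc3nnnn3C(C)(C)C)cc2)C(=O)c2ccccc2C1=O` gives 48000 nM.
Compound 3 `CC1=C([Se]c2ccc(NC(c3ccc(C)cc3)c3nnnn3C(C)(C)C)cc2)C(=O)c2ccccc2C1=O` gives 36000 nM.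

Compound 3 holds the lower of the two numbers, yet the step of a 1.3-fold lower number from compound 2 to compound 3 (0.12 log units; within the scatter) lies within the scatter, so no order between these two can be claimed. Compound 1 stands only at a limit (the limit of >= 100000 nM in this assay, at which 1 of the 3 values shown sits).

Compound 4 `CC1=C([Se]c2ccc(NC(c3ccco3)c3nnnn3C(C)(C)C)cc2)C(=O)c2ccccc2C1=O` differs from compound 3 by furan-2-yl in place of 4-methylphenyl on a saturated chain carbon bound to an aromatic carbon and a nitrogen on an aromatic ring. For the measured compounds named here, the one measured step at that same place, a 1.3-fold lower number from compound 2 to compound 3 (0.12 log units; within the scatter), was within the scatter, and it set hydrogen against 4-methylphenyl rather than one aromatic ring against another; no measured pair sets furan-2-yl against 4-methylphenyl. The expectation for this assay is therefore a step within the scatter, with no direction claimed beyond it. Compound 4 is expected at 40000 nM, within 20000 nM to 90000 nM. The expected step is a 1.1-fold higher number from compound 3 to compound 4 (0.05 log units; within the scatter).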

Compound 4, half-maximal inhibitory concentration: 5000 nM
Compound 4: the middle estimate sits 8.0-fold (0.90 log units) above what was measured, outside the stated range (below it).
By their numbers in this assay, from the lowest: compound 4; then compounds 3 and 2 (each within the scatter of the next). At a limit, above all of these: compound 1.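

In this assay, the saturated chain carbon bound to an aromatic carbon and a nitrogen on an aromatic ring now proves sensitive to which aromatic ring it carries: furan-2-yl in place of 4-methylphenyl gives a 7.2-fold lower number from compound 3 to compound 4 (0.86 log units; beyond the scatter) in the series. Set against hydrogen at the same place, furan-2-yl gives a 9.6-fold lower number from compound 2 to compound 4 (0.98 log units; beyond the scatter), whereas 4-methylphenyl gave only a 1.3-fold lower number from compound 2 to compound 3 (0.12 log units; within the scatter), so among these compounds an aromatic ring at this place does not by itself go with a clear step; furan-2-yl does. Nothing measured here accounts for this step.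

Open, on these data alone, is whether the step follows the ring oxygen or the five-membered ring itself. Thiophen-2-yl and phenyl at this place would separate the two, and a pyridin-2-yl group would test a different ring hetero atom.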